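Changing the Benzyl Group: From Chlorine to Tert-Butyl

The source may hold more compounds than are shown below. What is called first, only, known or untested is meant among the compounds shown, and "the series" means these compounds.

Measured so far in a functional assay on NCI-H460 cells (Homo sapiens) for cytotoxicity, read by MTT assay, with a stated time of 72 h; on this read-out lower numbers stand for stronger inhibition and higher numbers for weaker inhibition:
Compound 1, `CCN(CC)Cc1ccc2nc(NC(=O)N/N=C/c3cn(Cc4ccccc4Cl)c4ccccc34)sc2c1`, gives 980 nM.
Compound 2, `CCN(CC)Cc1ccc2nc(NC(=O)N/N=C3\C(=O)Nc4ccc(F)cc43)sc2c1`, gives 1060 nM.
Compound 3, `CN(C)Cc1ccc2nc(NC(=O)N/N=C/c3cn(Cc4ccccc4Cl)c4ccccc34)sc2c1`, gives 1600 nM.

All three numbers sit within the usual scatter of one another, so none of the compounds can be set apart from the others. Compound 3 is no exception: its nearest neighbour is compound 2 and its furthest is compound 1, and both gaps stay inside the scatter. The one step available among these compounds, a 1.6-fold higher number from compound 1 to compound 3 (0.21 log units; within the scatter), concerns the amine end of the shared core and is itself within the scatter.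

The step now followed lies at the opposite end. Compound 4, `CN(C)Cc1ccc2nc(NC(=O)N/N=C/c3cn(Cc4ccc(C(C)(C)C)cc4)c4ccccc34)sc2c1`, differs from compound 3 by 4-(tert-butyl)phenyl in place of 2-chlorophenyl on a saturated chain carbon bound to an aromatic nitrogen. For the measured compounds named here, no measured compound carries the 4-(tert-butyl)phenyl group, and no measured step bears on this change, so there is nothing to push the estimate away from compound 3 in either direction. The expected step is a 1.1-fold higher number from compound 3 to compound 4 (0.05 log units; within the scatter), that is, nothing beyond the scatter. Compound 4 is therefore estimated at 1800 nM in this assay, with a range from 700 nM to 4500 nM.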

Compound 4, half-maximal inhibitory concentration: 810 nM
For compound 4 the middle estimate is 2.2-fold (0.35 log units) above the measured one, and the stated range covers the measured number.
By their numbers in this assay, from the lowest: compounds 4, 1, 2 and 3 (each within the scatter of the next).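

In this assay, replacing 2-chlorobenzyl with 4-(tert-butyl)benzyl gives a 2.0-fold lower number from compound 3 to compound 4 (0.30 log units; within the scatter), the only step shown so far at this end of the molecule. The entering 4-(tert-butyl)phenyl group has 10 heavy atoms against 7 for 2-chlorophenyl and contains no chlorine, yet the two compounds cannot be told apart, so in this pair, the position on a saturated chain carbon bound to an aromatic nitrogen takes this change with no difference beyond the scatter. No separate measurement bears on this result, so what lies behind it remains unknown.

One step also cannot separate the loss of chlorine from the gain of tert-butyl, and a compound carrying plain benzyl or 4-chlorobenzyl at this position would help to pull those two apart. Going by these compounds, it also remains open whether a benzyl group bearing an amine or a carboxylic acid, or a longer chain between the aromatic nitrogen and the phenyl ring, would move the number beyond the scatter, and whether 4-(tert-butyl)benzyl would behave the same way alongside the diethylamino end of compound 1.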